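This account rests on a few compounds, and the source may have more. Where it says the series, first, only, none or still open, it means among the compounds named here.

Measured so far, in an ADME assay on microsomes from liver (Homo sapiens) for metabolic stability, using NADPH, with a stated time of 40 min, tested at 2 uM; on this read-out higher numbers stand for a longer-lived compound and lower numbers for a shorter-lived compound:
- compound 1, `CNC(=O)c1cccc2nc(-c3c[nH]c4c(F)c(F)c(F)cc34)ccc12`: 1.17 h
- compound 2, `Cc1cccc2c(-c3ccc4ccc(Cl)cc4n3)c[nH]c12`: 1.48 h
- compound 3, `Cc1cc(C)c2[nH]cc(-c3ccc4ccccc4n3)c2c1`: 1.57 h

Of these three, compound 1 gives the smallest number, but its gaps to compound 2 and to compound 3 both lie within the usual scatter of this assay, so the three measured compounds cannot be told apart on the numbers shown; none of them stands out as longer- or shorter-lived than the others.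

Compound 4, `CC(C)NC(=O)c1cccc2nc(-c3c[nH]c4c(F)c(F)c(F)cc34)ccc12`, has not yet been measured. It differs from compound 1 in one place only: isopropyl in place of methyl on an amide-type nitrogen. For the measured compounds named here, no pair of measured compounds differing in a single place is available here, so there is no comparable step to lean on. The change swaps one small group on the amide-type nitrogen for a somewhat larger one and adds nothing in the way of rings, donors or acceptors. On that basis the step from compound 1 to compound 4 is expected to be small, a 1.2-fold lower number from compound 1 to compound 4 (0.07 log units; within the scatter), and not clearly beyond the scatter in either direction. For compound 4 the estimated half-life in this assay is 1 h, with a likely range from 0.5 h to 2.2 h.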

Compound 4, half-life: 3.43 h
Beside the measured number, compound 4's estimate is 3.4-fold (0.54 log units) below it, and the stated range ends below it.
By their numbers in this assay, from the lowest: compounds 1, 2 and 3 (each within the scatter of the next); then compound 4.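

In this assay the amide-type nitrogen proves to be a place where a small change can be read: isopropyl in place of methyl gives a 2.9-fold higher number from compound 1 to compound 4 (0.47 log units; beyond the scatter), a modest step but one beyond the scatter, whereas the three earlier compounds could not be told apart on their numbers. The step swaps a group of 1 heavy atom for one of 3 heavy atoms, brings in no ring, hydrogen-bond donor or acceptor, and leaves the core of compound 1 untouched, so the whole difference in half-life belongs to this one substituent on that nitrogen. Nothing among the data shown explains why the longer half-life goes with the isopropyl group.

A single step cannot show whether the half-life keeps lengthening along a series such as ethyl, tert-butyl or a longer chain on the same nitrogen, or whether a cyclopropyl ring or a chain ending in a hydroxyl group would do the same. The compounds shown also leave open whether the step from methyl to isopropyl would hold if the fluorine atoms of the shared core were replaced by hydrogen.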